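Oxetanyl amide to methyl-oxadiazole on the piperidine carbon

The source may report more compounds than this note shows. Statements on the series, on what has been measured and on what is new or still open speak of the compounds shown alone.

Measured compounds:
compound 1 `CCN1CC(NC(=O)[C@@H]2CCCN(S(=O)(=O)c3ccc(S(=O)(=O)N(CC)CC)cc3)C2)C1` — > 30000 nM
compound 2 `CCN(CC)S(=O)(=O)c1ccc(S(=O)(=O)N2CCC[C@@H](C(=O)NC3COC3)C2)cc1` — 13800 nM

In a functional assay on BXPC-3 cells (Homo sapiens) for inhibition, read by MTT assay, with a stated time of 7 days (a higher number here means a weaker inhibitor, a lower number a stronger inhibitor), compound 1 gives only a limit, > 30000 nM, not a number. Among the measured compounds shown here, compound 2, in the same assay, gives 13800 nM, the only number among the two values shown. For the measured compounds named here, the one measured step, an at least 2.1-fold lower number from compound 1 to compound 2 (0.33 log units; beyond the scatter), is counted from a limit of > 30000 nM in this assay, at which 1 of the 2 values shown sits, and so gives only a minimum size.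

Compound 3 `CCN(CC)S(=O)(=O)c1ccc(S(=O)(=O)N2CCC[C@@H](c3nc(C)no3)C2)cc1` is not yet measured. It differs from compound 2 by 3-methyl-1,2,4-oxadiazol-5-yl in place of (oxetan-3-yl)carbamoyl on a saturated ring carbon. Going by the values given here, no measured step touches this change; the only step known concerns the group on the amide-type nitrogen, which here disappears together with the carbamoyl. The series so far sits at weak inhibition, and no shown step gives a direction for this change, so no step beyond the scatter is expected, a 1.1-fold higher number from compound 2 to compound 3 (0.04 log units; within the scatter). Compound 3 is estimated at 15000 nM, within 4000 nM to 50000 nM.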

Compound 3, half-maximal inhibitory concentration: 2900 nM
Compound 3: middle estimate off by 5.2-fold (0.71 log units), on the high side; measured number below the stated range.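

In this assay, the saturated ring carbon two ring bonds from the ring nitrogen does not depend on the carbamoyl: 3-methyl-1,2,4-oxadiazol-5-yl in place of (oxetan-3-yl)carbamoyl gives a 4.8-fold lower number from compound 2 to compound 3 (0.68 log units; beyond the scatter). The earlier step varied only the group on the amide nitrogen, whereas this one shows that replacing the whole carbamoyl, with its hydrogen-bond donor, with a five-membered aromatic ring with no donor keeps inhibition and moves it further than that step could show. Measured against the (1-ethylazetidin-3-yl)carbamoyl, the change reads as an at least 10-fold lower number from compound 1 to compound 3 (1.01 log units; beyond the scatter), a minimum size only, with compound 1 at a limit: the limit of > 30000 nM in this assay, at which 1 of the 3 values shown sits.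

The compounds shown do not separate the effect of losing the amide from that of adding the oxadiazole ring. As far as these compounds go, how a longer chain such as ethyl in place of the 3-methyl, a 1,3,4-oxadiazole or a carboxylic acid at this ring carbon would read remains open.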